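A few compounds are considered here, and "the series" means these few. Any claim that something is new, unique, unknown or untested is made for them only; others in the source may bear on it.

Compound 2 `CN(C)CCCCOC(=O)Nc1ccc(Cn2nc(-c3ccc(C#N)cc3)c3ccccc3c2=O)cc1` is one of two compounds tested in an ADME assay on Huh-7 cells (Homo sapiens) for cytotoxicity, read by MTT assay, with a stated time of 48 h (a higher number here means that more compound is tolerated, a lower number that less compound is tolerated), where compound 2 gives 37000 nM. Compound 1 `CN(C)CCCCOC(=O)Nc1ccc(Cn2nc(-c3ccccc3)c3ccccc3c2=O)cc1` differs only by hydrogen in place of the cyano, and in this assay compound 1 gives 16000 nM. Compound 2 therefore stands highest of the two, the step of a 2.3-fold higher number from compound 1 to compound 2 (0.36 log units; beyond the scatter) being modest but beyond the scatter. Compound 3 `CN(C)CCCCOC(=O)Nc1ccc(Cn2nc(-c3ccccc3F)c3ccccc3c2=O)cc1` has not yet been measured in this assay. Its difference from compound 2 is 2-fluorophenyl in place of 4-cyanophenyl on an aromatic carbon. Among the measured compounds shown here, the only measured step that bears on this change is the step from compound 1 to compound 2, which removed a hydrogen for a cyano; compound 3 loses that cyano again but gains a fluorine, for which no measured step exists. Compound 3 is therefore expected to land near compound 1, with a step of a 2.1-fold lower number from compound 2 to compound 3 (0.31 log units; beyond the scatter) expected, and its value in this assay is estimated at 18000 nM, with a range from 8000 nM to 40000 nM.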

Compound 3, half-maximal cytotoxic concentration: 52500 nM
The estimate for compound 3 lay 2.9-fold (0.46 log units) below the measured number, and the stated range ends below it.
By their numbers in this assay, from the lowest: compound 1; then compounds 2 and 3 (each within the scatter of the next).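

In this assay, the exchange at this aromatic carbon gives a 1.4-fold higher number from compound 2 to compound 3 (0.15 log units; within the scatter), so 2-fluorophenyl and 4-cyanophenyl cannot be told apart here, although they differ in both substituent and ring position. Against the unsubstituted phenyl, fluoro in place of hydrogen gives a 3.3-fold higher number from compound 1 to compound 3 (0.52 log units; beyond the scatter), which means that compound 1 now sits beyond the scatter from both substituted compounds and that the cyano is not the only substituent at this position that goes with more compound being tolerated. No data given here explain either step. Going by these compounds, it remains open whether the fluoro step depends on where the fluorine sits on the phenyl ring. A methoxy or an amino group on that ring might also give a number close to those of compound 2 and compound 3, or one closer to compound 1.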